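This account rests on a few compounds, and the source may have more. Where it says the series, first, only, none or still open, it means among the compounds named here.

In a functional assay on SK-BR-3 cells (Homo sapiens) for antiproliferative activity, read by MTT assay, with a stated time of 72 h (on this read-out higher numbers stand for weaker inhibition and lower numbers for stronger inhibition), compound 1 `CCN(CC)CCNc1cc(C)c2cc(NC(=O)c3ccc(Cl)c(Cl)c3)ccc2n1` gives 3710 nM, compound 2 `CNc1cc(C)c2cc(NC(=O)c3ccc(Cl)c(Cl)c3)ccc2n1` gives 6350 nM, and compound 3 `CCN1CCN(c2cc(C)c3cc(NC(=O)c4ccc(Cl)c(Cl)c4)ccc3n2)CC1` gives 2160 nM. For the measured compounds named here, compound 3 holds the lowest of the three numbers, but only the step of a 2.9-fold lower number from compound 2 to compound 3 (0.47 log units; beyond the scatter) is beyond the scatter; the gap between compound 1 and compound 3 is within it. Compound 4 `Cc1cc(NCCN2CCCCC2)nc2ccc(NC(=O)c3ccc(Cl)c(Cl)c3)cc12` is not yet measured. It differs from compound 3 in one place: (2-(piperidin-1-yl)ethyl)amino in place of 4-ethylpiperazin-1-yl on an aromatic carbon. The (2-(piperidin-1-yl)ethyl)amino group of compound 4 resembles the (2-(diethylamino)ethyl)amino group of compound 1, so the step of a 1.7-fold lower number from compound 1 to compound 3 (0.23 log units; within the scatter) is the closest guide, and it stayed within the scatter. The step of a 2.9-fold lower number from compound 2 to compound 3 (0.47 log units; beyond the scatter) was modest and concerned a much smaller methylamino group, so it bears less on this change. Because the step of a 1.7-fold lower number from compound 1 to compound 3 (0.23 log units; within the scatter) was within the scatter, a step of about the same size in the opposite direction is expected, a 1.5-fold higher number from compound 3 to compound 4 (0.17 log units; within the scatter), which is not beyond the scatter. Compound 4 is therefore estimated to give 3200 nM, with a likely range from 1300 nM to 8000 nM.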

Compound 4, half-maximal inhibitory concentration in the SK-BR-3 assay: 1800 nM
Beside the measured number, compound 4's estimate is 1.8-fold (0.25 log units) above it, within the range that was stated.
By their numbers in the SK-BR-3 assay, from the lowest: compounds 4, 3, 1 and 2 (each within the scatter of the next, the first and the last beyond it).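

In the SK-BR-3 assay, replacing the 4-ethylpiperazin-1-yl group with the (2-(piperidin-1-yl)ethyl)amino group gives a 1.2-fold lower number from compound 3 to compound 4 (0.08 log units; within the scatter), while the other comparisons give a 3.5-fold lower number from compound 2 to compound 4 (0.55 log units; beyond the scatter) and, for piperidin-1-yl in place of diethylamino at the chain end, a 2.1-fold lower number from compound 1 to compound 4 (0.31 log units; beyond the scatter). For the compounds shown here, in a physicochemical assay for solubility (on this read-out higher numbers stand for higher solubility and lower numbers for lower solubility), compound 3 gives 11.3 ug/mL and compound 4 gives 70.8 ug/mL, the first solubility values. Within the scatter in the SK-BR-3 assay yet beyond it in the physicochemical assay, this change at the aromatic carbon separates the two compounds on solubility alone: the measured solubility of compound 3, 11.3 ug/mL, and of compound 4, 70.8 ug/mL, a 6.3-fold higher number (0.80 log units; beyond the scatter)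

This change alters the ring and the chain together, and the compounds shown do not separate the two. A morpholin-4-yl ring on the same ethylamino chain, or a longer propyl chain, remains an open test of both read-outs.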